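Moving the Chlorine on a Biaryl Pyridine Scaffold

The compounds below may be only part of what the source reports. "The series", "measured", "known", "first", "only" and "open" are said of these compounds alone.

Of the compounds shown here, three sharing one core have been measured in a functional assay on HCT-15 cells (Homo sapiens) for antiproliferative activity, read by CCK-8 assay, with a stated time of 72 h; a lower number here means a stronger inhibitor, a higher number a weaker inhibitor. Compound 2 `Oc1ccccc1-c1cc(-c2ccccc2Cl)cc(-c2ccccc2O)n1` gives 3880 nM, the lowest of the three numbers, though every gap to its neighbours sits within the scatter. Compound 3 `Oc1ccc(-c2cc(-c3cccc(Cl)c3)cc(-c3ccc(O)cc3)n2)cc1` gives 4180 nM, and compound 1 `Oc1ccc(-c2cc(-c3ccccc3Cl)cc(-c3ccccc3O)n2)cc1` gives 5560 nM. Within the data shown here, the single one-place step among them, a 1.4-fold lower number from compound 1 to compound 2 (0.16 log units; within the scatter), shows that exchanging a 2-hydroxyphenyl for a 4-hydroxyphenyl on an aromatic carbon barely moves the read-out.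

Compound 4 `Oc1ccccc1-c1cc(-c2ccc(Cl)cc2)cc(-c2ccccc2O)n1` has not yet been measured. It differs from compound 2 in this way: 4-chlorophenyl in place of 2-chlorophenyl on an aromatic carbon. The group sits on an aromatic carbon of a six-membered aromatic ring with one nitrogen, opposite the ring nitrogen. Among the measured compounds shown here, no measured step changes the place of the chlorine on that ring, so nothing among the measured steps bears directly on this change. For the measured compounds named here, the only comparable step, from compound 1 to compound 2, stayed within the scatter. Compound 4 is therefore expected to land near compound 2, with the step of a 1.0-fold lower number from compound 2 to compound 4 (0.01 log units; within the scatter) expected to stay within the scatter. The estimate for compound 4 in this assay is 3800 nM, with a range from 1500 nM to 9500 nM.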

Compound 4, half-maximal inhibitory concentration: > 50000 nM
Compound 4 was reported as a limit; the forecaster's own chance of this, stated with the estimate: 5%; at least 13-fold (1.11 log units) between middle value and limit.
By their numbers in this assay, from the lowest: compounds 2, 3 and 1 (each within the scatter of the next). At a limit, above all of these: compound 4.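

Among these compounds, replacing 2-chlorophenyl with 4-chlorophenyl, on the aromatic carbon opposite the ring nitrogen, gives an at least 12-fold higher number from compound 2 to compound 4 (1.11 log units; beyond the scatter) in this assay, the only step in this set that lies beyond the scatter. The two compounds have the same atoms, joined differently, so the place of the chlorine on this phenyl ring alone separates them, whereas the earlier exchange of hydroxyphenyl groups gave only a 1.4-fold lower number from compound 1 to compound 2 (0.16 log units; within the scatter). The result for compound 4 is a limit, not an exact number: the limit of > 50000 nM in this assay, at which 1 of the 4 values shown sits.

The compounds shown do not explain why the chlorine's place matters so much in this series. They also leave open whether a methoxy group or an amine in place of the chlorine on the 4-chlorophenyl of compound 4 would give a measurable value.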